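Swapping a pyridinyloxy group for a pyridinone on the core

A few compounds are considered here, and "the series" means these few. Any claim that something is new, unique, unknown or untested is made for them only; others in the source may bear on it.

Of the compounds shown here, two have been measured in a functional assay for inhibition of sodium/hydrogen exchanger (Oryctolagus cuniculus); on this read-out higher numbers stand for weaker inhibition and lower numbers for stronger inhibition. Compound 1 `CS(=O)(=O)c1cc(C(=O)N=C(N)N)ccc1Oc1cccnc1` gives 76 nM in this assay, and compound 2 `CCc1cc(Oc2cccnc2)c(S(C)(=O)=O)cc1C(=O)N=C(N)N` gives 27 nM. Among the compounds with values here, compound 2 therefore stands at the lower of the two numbers, and the only measured step, a 2.8-fold lower number from compound 1 to compound 2 (0.45 log units; beyond the scatter), shows that adding the ethyl group strengthened inhibition to a modest degree.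

Compound 3 `CCc1cc(-n2ccc(=O)cc2)c(S(C)(=O)=O)cc1C(=O)N=C(N)N` keeps the ethyl, the methylsulfonyl group and the acylguanidine of compound 2, but differs in one place: a group of 7 heavy atoms (5 carbon, 1 nitrogen, 1 oxygen; one six-membered aromatic ring with 1 hetero atom) in place of a group of 7 heavy atoms (5 carbon, 1 nitrogen, 1 oxygen; one six-membered aromatic ring with 1 hetero atom), on an aromatic carbon. The same atoms are present, joined differently, so a ring linked through oxygen is replaced by a ring bearing a double bond outside the aromatic system, attached directly to the core.

Within the data shown here, no measured step bears on this change; the only step available concerns the ethyl group, not this part of the molecule. The expectation for compound 3 therefore rests on compound 2 alone, with wide uncertainty, and a somewhat weaker result is expected, a 3.0-fold higher number from compound 2 to compound 3 (0.47 log units; beyond the scatter). Compound 3 is estimated at 80 nM, within a range of 15 nM to 400 nM.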

Compound 3, half-maximal inhibitory concentration: 930 nM
Compound 3: the middle estimate sits 12-fold (1.07 log units) below what was measured, outside the stated range (above it).
By their numbers in this assay, from the lowest: compound 2; then compound 1; then compound 3.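

In this assay this position proves sensitive to how the ring is joined to the core, which the ethyl step could not show. The group keeps the same kinds and numbers of atoms, with the same counts of hydrogen-bond donors and acceptors and no net charge, yet the exchange gives a 34-fold higher number from compound 2 to compound 3 (1.54 log units; beyond the scatter) and ranks as a large step, so those tallies alone do not settle the outcome at this place. No measurement shown here accounts for the size of this step.

Two things change together in this single step: the oxygen link to the core is gone, and the ring now carries a carbonyl, so the compounds shown cannot say which of the two matters more. A directly attached pyridin-3-yl ring, which has no oxygen link and no carbonyl, or a phenoxy group, which keeps the oxygen link but has no ring nitrogen, would help to pull these features apart at this position on the shared core.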